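The compounds below may be only part of what the source reports. "The series", "measured", "known", "first", "only" and "open" are said of these compounds alone.

Measured compounds:
compound 1, `O=C(Nc1cccc(-n2cc(-c3ccncc3)c(-c3cc(O)cc(Cl)c3)n2)c1)Nc1ccc(Cl)c(Cl)c1`: 100%
compound 2, `COc1cc(Cl)cc(-c2nn(-c3cccc(NC(=O)Nc4cc(C(F)(F)F)cc(C(F)(F)F)c4)c3)cc2-c2ccncc2)c1`: 98%

Both compounds were tested in a functional assay on KM12 cells (Homo sapiens) for inhibition, read by sulforhodamine B assay, with a stated time of 48 h, tested at 0.1 uM; a higher number here means a weaker effect of the compound at the concentration tested, a lower number a stronger effect. In this assay compound 1 gives 100%, and compound 2 gives 98%. These two numbers sit within the usual scatter of each other, so compound 2 stands side by side with compound 1 rather than apart from it: at the concentration used, neither compound shows an effect that can be told from no effect at all.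

Compound 3, `COc1cc(Cl)cc(-c2nn(-c3cccc(NC(=O)Nc4cccc(C(F)(F)F)c4)c3)cc2-c2ccncc2)c1`, has not been measured. It differs from compound 2 in one place: hydrogen in place of trifluoromethyl on an aromatic carbon. Within the data shown here, no pair of measured compounds that differ in only one place is available, so there is no measured step to lean on. What is known is that compound 2 gives 98% and compound 1 gives 100%, both numbers meaning essentially no inhibition. Taking away one trifluoromethyl is therefore expected to move the number by no more than the scatter, an expected step of a number 1 percentage points lower from compound 2 to compound 3 (within the scatter). Compound 3 is estimated to give 97% in this assay, within a range of 85% to 105%.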

Compound 3, a percentage reported as activity, at one concentration (the size of the read-out at that concentration, not a potency): 95%
Compound 3: the middle estimate sits 2 percentage points above what was measured; the measured number falls inside the stated range.
By their numbers in this assay, from the lowest: compounds 3, 2 and 1 (each within the scatter of the next).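

Among these compounds, putting hydrogen in place of trifluoromethyl on this aromatic carbon gives a number 3 percentage points lower from compound 2 to compound 3 (within the scatter) in this assay, and this is the first comparison here between two compounds that differ in only one place. At this concentration, compound 2 and compound 3 cannot be told apart, so this trifluoromethyl can give way to hydrogen without a measurable difference in this read-out. Both compounds sit close to no effect at all, however, so the result says little about whether this position could matter under conditions where an effect appears, and no measured information bears on the result.

The compounds shown leave open whether a different group on this aromatic carbon, such as an amine or a carboxylic acid, would give a number that stands clearly apart from these. They also leave open what would happen if the remaining trifluoromethyl of compound 3 were replaced, and whether any such change would produce a clear effect in this cell assay.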